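Adding a Second Halogen to the Outer Ring of Compound 1

The compounds below may be only part of what the source reports. "The series", "measured", "known", "first", "only" and "open" are said of these compounds alone.

Of the compounds shown here, two built on the same core have been tested in an assay for inhibition of Indoleamine 2,3-dioxygenase 1 (Homo sapiens), read by spectrophotometry, with stated times of 1 h and 4 h; a higher number here means a weaker inhibitor, a lower number a stronger inhibitor. Compound 1 `CC(=O)Nc1ccc(S(=O)(=O)NNc2ccc(F)cc2)cc1` carries a fluoro group on its outer aromatic ring and gives 79 nM in this assay. Compound 2 `CC(=O)Nc1ccc(S(=O)(=O)NNc2ccc(Cl)cc2)cc1` has a chloro group in place of that fluoro and gives 155 nM. The step of a 2.0-fold higher number from compound 1 to compound 2 (0.29 log units; within the scatter) is the only one measured, and it lies within the scatter, so compound 1 shows the smaller of the two numbers without standing apart from compound 2.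

Compound 3 `CC(=O)Nc1ccc(S(=O)(=O)NNc2ccc(F)c(Cl)c2)cc1` keeps the fluoro group of compound 1 and adds a further substituent: chloro in place of hydrogen on an aromatic carbon, ortho to a fluoro group and meta to a large group. For the measured compounds named here, no measured step shows the effect of adding a halogen while another is kept, so the swap from compound 1 to compound 2 is the nearest guide, and that swap stayed within the scatter. A change of about that size is therefore expected from compound 1 to compound 3, a 1.5-fold higher number from compound 1 to compound 3 (0.18 log units; within the scatter), in either direction or none at all. Compound 3 is estimated to give 120 nM in this assay, within the range 40 nM to 350 nM.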

Compound 3, half-maximal inhibitory concentration: 110 nM
Compound 3: the middle estimate sits 1.1-fold (0.04 log units) above what was measured, within the range that was stated.
By their numbers in this assay, from the lowest: compounds 1, 3 and 2 (each within the scatter of the next).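

Adding chloro in place of hydrogen on an aromatic carbon, ortho to a fluoro group and meta to a large group, gives a 1.4-fold higher number from compound 1 to compound 3 (0.14 log units; within the scatter) in this assay. For the compounds shown here, this is the first measured case in which a second halogen joins the outer ring while the first stays in place, and the single added chlorine atom leaves compound 3 within the scatter of compound 1, so the two cannot be told apart here. For this pair, then, the position accepts chloro alongside the fluoro group without a difference that can be read, although no measurement at hand offers an explanation for how close the two numbers lie.

At this position the compounds shown carry only hydrogen or chloro, so it remains open whether a methoxy group, an amine or a carboxylic acid there would also stay within the scatter of compound 1. It is also open whether chloro at this position would give a similar number if the fluoro group were replaced by hydrogen, since no compound shown separates the two halogens in that way.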